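Notes on the benzyl amide change from compound 1 to compound 4

This account rests on a few compounds, and the source may have more. Where it says the series, first, only, none or still open, it means among the compounds named here.

Three compounds carry measured numbers. Compound 1 `COc1ccc(CNC(=O)c2nc(-c3ccc(F)cc3)n(CC[C@@H](O)C[C@@H](O)CC(=O)O)c2C2CC2)cc1F` gives 890 nM in a functional assay on L6 cells (Rattus norvegicus) for inhibition, read by scintillation counting, with a stated time of 3 h; on this read-out lower numbers stand for stronger inhibition and higher numbers for weaker inhibition. Compound 3 `Cc1ccc(CNC(=O)c2nn(-c3ccc(F)cc3)c(CC[C@@H](O)C[C@@H](O)CC(=O)O)c2C(C)C)cc1` gives 730 nM in this assay, a gap to compound 1 that lies within the scatter, so no order between the two is claimed. Compound 2 `CC(C)c1c(C(=O)NCc2ccccc2)nc(-c2ccc(F)cc2)n1CC[C@@H](O)C[C@@H](O)CC(=O)O` gives 3030 nM in this assay, and its gap to compound 1 lies beyond the scatter. Compound 1 thus stands second highest of the three numbers. Compound 4 `COc1cccc(CNC(=O)c2nc(-c3ccc(F)cc3)n(CC[C@@H](O)C[C@@H](O)CC(=O)O)c2C2CC2)c1` is not yet measured; it differs from compound 1 in one place: 3-methoxyphenyl in place of 3-fluoro-4-methoxyphenyl on a saturated chain carbon bound to an amide-type nitrogen. For the measured compounds named here, no step between measured compounds isolates this change, so only a modest shift in this assay is expected, if any, toward a somewhat higher number. For compound 4 the estimate in this assay is 1200 nM, with a range of 500 nM to 3000 nM. That would mean an expected step of a 1.3-fold higher number from compound 1 to compound 4 (0.13 log units; within the scatter).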

Compound 4, half-maximal inhibitory concentration: 538 nM
Beside the measured number, compound 4's estimate is 2.2-fold (0.35 log units) above it, within the range that was stated.
By their numbers in this assay, from the lowest: compounds 4, 3 and 1 (each within the scatter of the next); then compound 2.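

In this assay, the first step isolating this position is a 1.7-fold lower number from compound 1 to compound 4 (0.22 log units; within the scatter), so compound 1 and compound 4 are not ordered. At this amide, 3-methoxybenzyl and 3-fluoro-4-methoxybenzyl therefore stand within the scatter of each other, on the core of compound 1. No measurement bears on the reason for this step. Open, going by these compounds, is whether 4-methoxybenzyl or 3-fluorobenzyl, each keeping one of the two substituents, would also stay within the scatter of compound 1. A 3-chlorobenzyl or 3-hydroxybenzyl group would show how far this position tolerates other substituents.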